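The source may report more compounds than this note shows. Statements on the series, on what has been measured and on what is new or still open speak of the compounds shown alone.

Three analogues sharing one core have been measured in a functional assay on MCF7 cells (Homo sapiens) for inhibition, read by CCK-8 assay, with a stated time of 48 h; a lower number here means a stronger inhibitor, a higher number a weaker inhibitor. Compound 1 `Cc1ccc(NC(=S)NC(=O)c2cn(-c3ccccc3)nc2-c2ccc(F)cc2)cc1` gives 5440 nM, compound 2 `Cc1ccc(NC(=S)NC(=O)c2cn(-c3ccccc3)nc2-c2ccc(Cl)cc2)cc1` gives 5980 nM, and compound 3 `Cc1ccc(-c2nn(-c3ccccc3)cc2C(=O)NC(=S)Nc2ccc(Cl)cc2)cc1` gives 6210 nM. For the measured compounds named here, the only single-point step among them is a 1.1-fold higher number from compound 1 to compound 2 (0.04 log units; within the scatter). The number for compound 3 is the highest of the three, yet its gaps to compound 2 and to compound 1 both lie within the scatter, so no ordering can be read from them. Compound 4 `Cc1ccc(NC(=S)NC(=O)c2cn(-c3ccccc3)nc2-c2ccc(C)cc2)cc1` differs from compound 3 by methyl in place of chloro on an aromatic carbon. Going by the values given here, no measured step replaces a halogen by a methyl; the closest comparison, the halogen swap between the first two compounds, stayed within the scatter. The step of a 1.0-fold lower number from compound 3 to compound 4 (0.01 log units; within the scatter) is therefore expected to be none beyond the scatter. Compound 4 is estimated at 6000 nM, with a range from 3000 nM to 12000 nM.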

Compound 4, half-maximal inhibitory concentration: 5660 nM
Estimate against measurement, compound 4: 1.1-fold (0.03 log units) above; low and high end bracket the measured number.
By their numbers in this assay, from the lowest: compounds 1, 4, 2 and 3 (each within the scatter of the next).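

Methyl now joins fluoro and chloro as a substituent on an aromatic carbon para to a large group, and in this assay none of the three separates from the others: a 1.0-fold higher number from compound 1 to compound 4 (0.02 log units; within the scatter) stays within the scatter. The chloro-to-methyl change reads alike in two places, as 4-chlorophenyl to 4-methylphenyl in a 1.1-fold lower number from compound 2 to compound 4 (0.02 log units; within the scatter) and as (4-chlorophenyl)amino to (4-methylphenyl)amino in a 1.1-fold lower number from compound 3 to compound 4 (0.04 log units; within the scatter). No supporting evidence bears on this result.

On these data alone, whether an amine, a carboxylic acid or a longer chain at either place would move the number beyond the scatter remains open.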